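Halogen swap on the pendant phenyl of compound 3

The compounds below may be only part of what the source reports. "The series", "measured", "known", "first", "only" and "open" are said of these compounds alone.

Compound 3 `O=C(Nn1c(-c2cccc([N+](=O)[O-])c2)nc2c(-c3ccc(Cl)cc3)n[nH]c2c1=O)c1ccccc1` stands highest of the three numbers in a functional assay on SK-MEL-2 cells (Homo sapiens) for cytotoxicity, read by sulforhodamine B assay, with a stated time of 2 days, tested at 100 uM (on this read-out higher numbers stand for more inhibition at the one concentration tested (going by the name of the read-out) and lower numbers for less inhibition), with 89%; compound 2 `O=C(Nn1c(-c2cccc([N+](=O)[O-])c2)nc2c(-c3cccc(Cl)c3)n[nH]c2c1=O)c1ccccc1` gives 78.2% and compound 1 `O=C(Nn1c(-c2cccc([N+](=O)[O-])c2)nc2c(-c3ccc(F)cc3)n[nH]c2c1=O)c1cccnc1` gives 24.5%. Going by the values given here, the one step within the set, a number 10.8 percentage points higher from compound 2 to compound 3 (beyond the scatter), moves the chloro from one position to another and does not touch the halogen itself. Compound 4 `O=C(Nn1c(-c2cccc([N+](=O)[O-])c2)nc2c(-c3ccc(F)cc3)n[nH]c2c1=O)c1ccccc1` carries fluoro in place of chloro on an aromatic carbon relative to compound 3. Among the compounds with values here, no measured step bears directly on this change. Compound 1 also carries the fluoro yet differs from compound 4 in its amide as well, so its value only hints at a weaker read-out. A downward step a number 24 percentage points lower from compound 3 to compound 4 (beyond the scatter) is therefore expected for compound 4, with wide uncertainty. Compound 4 is estimated at 65%, between 35% and 90%.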

Compound 4, a percentage reported as inhibition, at one concentration (the size of the read-out at that concentration, not a potency): 88.5%
Estimate against measurement, compound 4: 23.5 percentage points below; the range from low to high includes it.
By their numbers in this assay, from the lowest: compound 1; then compound 2; then compounds 4 and 3 (each within the scatter of the next).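

At the pendant phenyl, fluoro in place of chloro leaves the read-out unchanged, with a number 0.5 percentage points lower from compound 3 to compound 4 (within the scatter), while a number 10.3 percentage points higher from compound 2 to compound 4 (beyond the scatter) places the 4-fluorophenyl, like the 4-chlorophenyl, beyond the 3-chlorophenyl of compound 2. The low value of compound 1 therefore goes with its amide and not with its fluoro: a number 64 percentage points higher from compound 1 to compound 4 (beyond the scatter), with phenyl in place of pyridin-3-yl on a carbonyl carbon. No supporting evidence bears on these steps.

Open, on these data alone, is whether a bromo or a methoxy on the same carbon would keep the read-out. Also open, as far as these compounds go, is whether the single-concentration read-out hides a difference in potency between compound 3 and compound 4.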